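A few compounds are considered here, and "the series" means these few. Any claim that something is new, unique, unknown or untested is made for them only; others in the source may bear on it.

Working notes on the series in an ADME assay on Vero cells (Chlorocebus sabaeus) for inhibition; on this read-out lower numbers stand for higher toxicity in this test and higher numbers for lower toxicity in this test.

Compound 1 `COc1ccc(/C=C2\CCC/C(=C\c3ccc(OC)cc3)C2=O)cc1` and compound 2 `COc1ccc(/C=C2\CCC/C(=C\c3ccccc3)C2=O)cc1` share a core and differ in one place. In this assay compound 1 gives 178000 nM, and compound 2 gives 291000 nM. The change between them, (methoxy in place of hydrogen on an aromatic carbon), gave a 1.6-fold lower number from compound 2 to compound 1 (0.21 log units; within the scatter).

Compound 3 `COc1cccc(/C=C2\CCC/C(=C\c3ccc([N+](=O)[O-])cc3)C2=O)c1OC` carries a different core; how its core differs from that of compound 2 is not broken down here. In this assay compound 3 is known only as a limit, < 10000 nM. Going by the values given here, this is the only one of the values shown that sits at the limit of < 10000 nM in this assay, at which 1 of the 3 values shown sits.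

Compound 4 `COc1cc([N+](=O)[O-])ccc1/C=C1\CCC/C(=C\c2cccc(OC)c2OC)C1=O` is not yet measured. It differs from compound 3 by methoxy in place of hydrogen on an aromatic carbon. This is the same kind of change as that from compound 2 to compound 1, but the place is not identical: in compound 1 the entering methoxy sits para to a large group, whereas in compound 4 it sits ortho to a large group and meta to a nitro group.

Compound 4 is expected at 7000 nM, with a range from 1500 nM to 20000 nM. Among the compounds with values here, the expected step is a step that the limit leaves unreadable from compound 3 to compound 4, set beside a 1.6-fold lower number from compound 2 to compound 1 (0.21 log units; within the scatter), which stayed within the scatter; that is the only measured guide to this kind of change. A substantial chance remains that the assay again reports only a limit rather than a number for compound 4.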

Compound 4, half-maximal cytotoxic concentration: 120000 nM
Estimate against measurement, compound 4: 17-fold (1.23 log units) below, and the stated range ends below it.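

In this assay, methoxy in place of hydrogen on an aromatic carbon gives an at least 12-fold higher number from compound 3 to compound 4 (1.07 log units; beyond the scatter), and the same change does not carry over in size from one core to the other: the same change on two cores in this assay, a 1.6-fold lower number (0.21 log units; within the scatter) from compound 2 to compound 1 and an at least 12-fold higher number (1.07 log units; beyond the scatter) from compound 3 to compound 4, at least 19-fold (1.29 log units) apart, beyond the scatter of two such steps

For compound 3 the reading < 10000 nM is a limit of the assay and not a number.

The comparison shows that this change cannot be assumed to transfer between cores in this series, but it rests on a single pair per core, and in compound 4 the entering methoxy sits ortho to a large group and meta to a nitro group, so it does not show whether the core, the place of the methoxy or the nitro group sets the gap.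

The compounds shown leave open whether the large step in this assay depends on the nitro group, and whether it would recur with an amine or a carboxylic acid in the place of that group. They also leave open whether a longer chain than methoxy on the same aromatic carbon would give a step of similar size, and whether methoxy at that same place on the core of compound 2 would repeat the step seen with compound 4.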